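The source may report more compounds than this note shows. Statements on the series, on what has been measured and on what is new or still open speak of the compounds shown alone.

Compound 3 `N#CC1=C(N)Oc2cc3oc(-c4ccccc4)cc(=O)c3c(O)c2C12C(=O)N(Cc1ccccc1)c1ccc(Cl)cc12` gives 36300 nM in a functional assay on K562 cells (Homo sapiens) for antiproliferative activity, read by MTT assay, with a stated time of 48 h (on this read-out lower numbers stand for stronger inhibition and higher numbers for weaker inhibition), the highest of the two numbers shown there. Compound 1 `CN1C(=O)C2(C(C#N)=C(N)Oc3cc4oc(-c5ccccc5)cc(=O)c4c(O)c32)c2cc(Br)ccc21` gives 4100 nM. Compound 2 `Cc1ccc2c(c1)C1(C(=O)N2Cc2ccccc2)C(C#N)=C(N)Oc2cc3oc(-c4ccccc4)cc(=O)c3c(O)c21` reaches only a limit of the assay in this assay, > 50000 nM. The move to compound 4 `N#CC1=C(N)Oc2cc3oc(-c4ccccc4)cc(=O)c3c(O)c2C12C(=O)N(Cc1ccccc1)c1ccc(Br)cc12` puts (bromo in place of chloro on an aromatic carbon). For the measured compounds named here, the only measured step on this ring is an at least 1.3-fold lower number from compound 2 to compound 3 (0.13 log units; that floor lies within the scatter), a change that stays within the scatter; the limit of > 50000 nM in this assay, at which 1 of the 3 values shown sits, keeps its true size open. One halogen replacing another at the same aromatic carbon is therefore expected to shift this assay by little, if at all, in either direction. Compound 4 is estimated at 30000 nM, between 12000 nM and 75000 nM. This estimate means a step of a 1.2-fold lower number from compound 3 to compound 4 (0.08 log units; within the scatter).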

Compound 4, half-maximal inhibitory concentration: 36400 nM
For compound 4 the middle estimate is 1.2-fold (0.08 log units) below the measured one; measured number inside the range.
By their numbers in this assay, from the lowest: compound 1; then compounds 3 and 4 (each within the scatter of the next). At a limit, above all of these: compound 2.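

Exchanging chloro for bromo at this aromatic carbon gives a 1.0-fold higher number from compound 3 to compound 4 (0.00 log units; within the scatter) in this assay, so the pair now shows that this halogen swap leaves the number within the scatter. With bromo held in place, the benzyl of compound 4 and the methyl of compound 1 on the ring nitrogen are separated by an 8.9-fold higher number from compound 1 to compound 4 (0.95 log units; beyond the scatter), a step beyond the scatter. The comparison of methyl with bromo, an at least 1.3-fold lower number from compound 2 to compound 4 (0.13 log units; that floor lies within the scatter), gives only a floor set by a limit: the limit of > 50000 nM in this assay, at which 1 of the 4 values shown sits. The compounds shown leave open whether an amine, a methoxy or a carboxylic acid on this aromatic carbon would shift the number beyond the scatter.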